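From Benzyl to 1,2-Oxazol-3-yl on the Amide Nitrogen

The compounds below may be only part of what the source reports. "The series", "measured", "known", "first", "only" and "open" are said of these compounds alone.

Of the compounds shown here, three sharing one core have been tested in a functional assay on CHO cells for agonist activity at Free fatty acid receptor 2 (Homo sapiens), read by cAMP accumulation; a lower number here means a smaller maximal response, a higher number a larger maximal response. Compound 1 `CC(C)C(C(N)=O)c1ccc(Cl)cc1` carries an unsubstituted amide. In this assay compound 1 gives < 30%, which is a limit of the assay rather than a number. Compound 2 `CC(C)[C@H](C(=O)NCc1ccccc1)c1ccc(Cl)cc1` bears a benzyl group on the amide nitrogen. In this assay compound 2 gives < 30%, again a limit and not a measured number. Compound 3 `CC(C)C(C(=O)Nc1nnn[nH]1)c1ccc(Cl)cc1` has a 1H-tetrazol-5-yl group in that position. In this assay compound 3 gives < 30%, also a limit. The step that the two limits leave unreadable from compound 1 to compound 3 therefore cannot be read in size. Compound 2 thus stands at the limit, as do the other two values: the limit of < 30% in this assay, at which 3 of the 3 values shown sit. Compound 4 `CC(C)[C@H](C(=O)Nc1ccon1)c1ccc(Cl)cc1` is not yet measured. It differs from compound 2 by 1,2-oxazol-3-yl in place of benzyl on an amide-type nitrogen. Among the compounds with values here, no measured step involves a 1,2-oxazol-3-yl group, so the only guidance is that every change tried so far left the response at the limit. Compound 4 is expected to give 20%, within 5% to 45%, most likely again reported only as a limit. The step that the limit leaves unreadable from compound 2 to compound 4 is expected to stay within the scatter.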

Compound 4, largest response reached (reported as efficacy), in percent of the reference or control that the assay uses: 90%
Beside the measured number, compound 4's estimate is 70 percentage points below it; the measured number lies above the stated range.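

Replacing benzyl with 1,2-oxazol-3-yl on the amide-type nitrogen produces a real change in this assay, with a number at least 60 percentage points higher from compound 2 to compound 4 (beyond the scatter). Within the data shown here, the group on this nitrogen can therefore decide whether the shared core gives a clear maximal response, something the earlier compounds could not show. Among those earlier compounds, no step can be read in size, and the values are limits of the assay rather than numbers: the limit of < 30% in this assay, at which 3 of the 4 values shown sit.

The change swaps one whole ring for another, so the compounds shown cannot separate the effect of the ring's size from that of its nitrogen and oxygen atoms. On these data alone, it also remains open whether a plain phenyl group or a pyridin-2-yl group on the same nitrogen would give a response like that of compound 4.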